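Thiophen-2-yl for 3-bromophenyl on compound 1

A few compounds are considered here, and "the series" means these few. Any claim that something is new, unique, unknown or untested is made for them only; others in the source may bear on it.

Compound 1 (`O=C(NCc1cccc(Br)c1)N1C(=O)c2ccccc2S1(=O)=O`) reads > 166 h in a physicochemical assay for pharmacokinetics (on this read-out higher numbers stand for a longer-lived compound and lower numbers for a shorter-lived compound), and that figure is a limit, not a number. Compound 2 (`O=C(c1ccccc1)N1Cc2ccccc2S1(=O)=O`) reads > 166 h in this assay and that too is a limit. Compound 3 (`O=C(c1ccccc1)N1Cc2ccccc2C1=O`) reads > 166 h in this assay and again this is a limit. Compound 1, compound 2 and compound 3 thus share the limit of > 166 h in this assay, at which 3 of the 3 values shown sit, and none of them has a number of its own.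

Compound 4 (`O=C(NCc1cccs1)N1C(=O)c2ccccc2S1(=O)=O`) keeps the core of compound 1 and differs from it in one place. The difference is thiophen-2-yl in place of 3-bromophenyl on a saturated chain carbon bound to an amide-type nitrogen and it puts thiophen-2-yl in place of 3-bromophenyl on a saturated chain carbon bound to an amide-type nitrogen.

Going by the values given here, no two measured compounds here differ in one place only, so the data give no measured size for such a change. The expectation therefore rests on the limit of compound 1 at > 166 h and on the same limit in the two other measured compounds. No change beyond the scatter is expected, and the estimated step is a step that the limit leaves unreadable from compound 1 to compound 4 in size. In this assay compound 4 is estimated at 200 h with an expected range from 110 h to 400 h. A limit rather than a number may well be expected for compound 4 too.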

Compound 4, half-life: > 166 h
Compound 4: no number, only a limit; the forecaster's own chance of this, stated with the estimate: 80%; the middle value lies beyond the limit too.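

Compound 4 gives only a limit in this assay, as compound 1 does, so no step between compound 1 and compound 4 can be read: the limit of > 166 h in this assay, at which 4 of the 4 values shown sit.

The compounds shown leave open where the half-life of each lies beyond that limit, and whether thiophen-2-yl in place of 3-bromophenyl changes it at all.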